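The compounds below may be only part of what the source reports. "The series", "measured", "known", "first", "only" and "open" are said of these compounds alone.

Measured so far: compound 1 `Cc1ccc(C(=O)N/N=C/c2ccccc2)c(O)c1`, 578000 nM; compound 2 `Cc1ccc(C(=O)N/N=C/c2ccc(Cl)cc2)c(O)c1`, 116000 nM.

Within the data shown here, in an ADME assay on cells (Mus musculus, strain BALB/C) for cytotoxicity, read by MTT assay, with a stated time of 24 h (on this read-out higher numbers stand for lower toxicity in this test and lower numbers for higher toxicity in this test), compound 2 gives the lowest of the two numbers, and its only neighbour is compound 1, separated from it by a 5.0-fold lower number from compound 1 to compound 2 (0.70 log units; beyond the scatter). Compound 3 `Cc1ccc(C(=O)N/N=C/c2ccc(N(C)C)cc2)c(O)c1` differs from compound 2 by dimethylamino in place of chloro on an aromatic carbon. Among the measured compounds shown here, the one measured step, a 5.0-fold lower number from compound 1 to compound 2 (0.70 log units; beyond the scatter), puts chloro in place of hydrogen and does not tell what happens when chloro is itself replaced, so no direction can be read off with confidence. Compound 3 is therefore expected near 250000 nM, in a wide range from 70000 nM to 900000 nM, which would mean a 2.2-fold higher number from compound 2 to compound 3 (0.33 log units; beyond the scatter).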

Compound 3, half-maximal cytotoxic concentration: 732000 nM
Estimate against measurement, compound 3: 2.9-fold (0.47 log units) below; measured number inside the range.
By their numbers in this assay, from the lowest: compound 2; then compounds 1 and 3 (each within the scatter of the next).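

In this assay, the two steps show that the change at this position depends on which group leaves: replacing chloro with dimethylamino gives a 6.3-fold higher number from compound 2 to compound 3 (0.80 log units; beyond the scatter) while replacing hydrogen with dimethylamino gives a 1.3-fold higher number from compound 1 to compound 3 (0.10 log units; within the scatter) and that second step stays within the scatter. Among these three compounds, only the chloro compound stands apart, and the larger dimethylamino group does not lower the number. Nothing available explains this difference. Still open, going by these compounds, is whether bromo, methoxy or a carboxylic acid at this position would behave like chloro or like dimethylamino.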